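This account rests on a few compounds, and the source may have more. Where it says the series, first, only, none or still open, it means among the compounds named here.

Measured so far:
compound 1, `CC(C)CNc1nc(N2CCN(Cc3ccccc3)CC2)ncc1C(=O)NCc1cccnc1`: 49 nM
compound 2, `O=C(NCc1ccccc1)c1cnc(N2CCN(C(=O)c3ccccc3)CC2)nc1NC1CC1`: "not active" (no number reported)

In a functional assay on HEK293 cells for agonist activity at transient receptor potential cation channel subfamily A member 1 (Homo sapiens), read by fluorescence and calcium flux, with stated times of 1 s and 60 s (on this read-out lower numbers stand for an effect already at smaller amounts and higher numbers for an effect only at larger amounts of compound), compound 1 gives 49 nM. In this assay compound 2 is reported as "not active" (no number reported), so no number stands for it and its place on the scale cannot be given; it can only be said that no effect was recorded at the amounts tested. Going by the values given here, compound 1 and compound 2 differ in more than one place, so no single step links them and nothing can be read from their pair beyond the two values themselves.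

Compound 3, `CCCCN1CCN(c2ncc(C(=O)NCc3ccccc3)c(NC3CC3)n2)CC1`, is to be measured in this assay. It differs from compound 2 by butyl in place of benzoyl on an amine nitrogen in a ring. Among the compounds with values here, with no numerical value for compound 2 and no step between measured compounds, the size of the step cannot be read from a prior case. The expectation is that compound 3 moves in the direction of an effect at smaller amounts than compound 2, most likely beyond the scatter, but the reach of that move is uncertain. Compound 3 is estimated at 400 nM, with a range from 60 nM to 4000 nM.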

Compound 3, half-maximal effective concentration: "not active" (no number reported)
The entry for compound 3 holds no number, so the estimate cannot be set against anything.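

In this assay compound 2 and compound 3 are both reported as not active, with no number for either, so no step can be read from this pair. No measured evidence bears on this result. The compounds shown leave open whether butyl and benzoyl on the amine nitrogen in the ring differ at all in their effect.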